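Dichloroacetanilides with varied meta substituents

The compounds below may be only part of what the source reports. "The series", "measured", "known", "first", "only" and "open" are said of these compounds alone.

Measured compounds:
compound 1 `Cc1cccc(NC(=O)C(Cl)Cl)c1`: "not determined" (no result reported)
compound 2 `O=C(Nc1cccc(F)c1)C(Cl)Cl`: "not determined" (no result reported)
compound 3 `O=C(Nc1cccc(C(F)(F)F)c1)C(Cl)Cl`: 8860 nM

In a functional assay on KB cells (Homo sapiens) for antiproliferative activity, read by MTT assay, with a stated time of 72 h (on this read-out lower numbers stand for stronger inhibition and higher numbers for weaker inhibition), compound 1 has no single number, and compound 2 likewise has no result. Only compound 3 gives a value, 8860 nM in this assay. Going by the values given here, no step between two measured compounds with a single change exists, so no measured step size is available. Compound 4 `O=C(Nc1cccc(SC(F)(F)F)c1)C(Cl)Cl` differs from compound 1 by (trifluoromethyl)sulfanyl in place of methyl on an aromatic carbon on an aromatic carbon of a six-membered aromatic ring of carbon only. With compound 1 unmeasured, the expectation for compound 4 rests on compound 3, because compound 3 gives 8860 nM in this assay; a step of no more than the usual scatter from that value is expected. Compound 4 is estimated at 6000 nM, range 1500 nM to 25000 nM.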

Compound 4, half-maximal inhibitory concentration: 4840 nM
Compound 4: the middle estimate sits 1.2-fold (0.09 log units) above what was measured; low and high end bracket the measured number.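

In this assay, going by these compounds alone, replacing trifluoromethyl with (trifluoromethyl)sulfanyl on the aromatic carbon gives a 1.8-fold lower number from compound 3 to compound 4 (0.26 log units; within the scatter), the only single-place comparison that can be read. This position therefore takes the added sulfur without a change beyond the scatter. No measurement here bears on why the two groups read alike. Steps from compound 1 and compound 2 cannot be read. Going by these compounds, whether an amine or a carboxylic acid in this place would move the number beyond the scatter remains open.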